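This account rests on a few compounds, and the source may have more. Where it says the series, first, only, none or still open, it means among the compounds named here.

Measured compounds:
- compound 1, `CC1(C)CC(NC(=S)Nc2ccc(C#N)cc2)c2cc(NS(C)(=O)=O)ccc2O1`: 11600 nM
- compound 2, `CC1(C)CC(NC(=S)Nc2ccc(Cl)cc2)c2cc(NS(C)(=O)=O)ccc2O1`: 11600 nM
- compound 3, `CC1(C)CC(NC(=O)Nc2ccc(C#N)cc2)c2cc(NS(C)(=O)=O)ccc2O1`: 19800 nM

All three were tested in a functional assay on thoracic aorta (Rattus norvegicus) for inhibition; on this read-out higher numbers stand for an effect only at larger amounts of compound and lower numbers for an effect already at smaller amounts. Compound 1 gives 11600 nM and compound 2 gives 11600 nM; compound 3 gives 19800 nM. The number for compound 3 sits within the usual scatter of both compound 1 and compound 2, so the three cannot be told apart on this read-out.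

Compound 4, `CC1(C)CC(NC(=O)Nc2ccc(Cl)cc2)c2cc(NS(C)(=O)=O)ccc2O1`, has not yet been measured. Compared with compound 3, the change is chloro in place of cyano on an aromatic carbon. The same swap has been seen once before, between compound 1 and compound 2, where it gave no change at the digits printed from compound 1 to compound 2 (within the scatter). Among the compounds with values here, that single step is the only guide here, and it points to no shift beyond the scatter. The expected step from compound 3 to compound 4 is therefore a 1.0-fold lower number from compound 3 to compound 4 (0.02 log units; within the scatter). Compound 4 is estimated at 19000 nM, with a range from 9000 nM to 40000 nM.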

Compound 4, half-maximal effective concentration: > 30000 nM
Compound 4: a limit, no number (the forecaster's own chance of this, stated with the estimate: 10%); middle value at least 1.5-fold (0.19 log units) from the limit.
By their numbers in this assay, from the lowest: compounds 1, 2 and 3 (each within the scatter of the next). At a limit, above all of these: compound 4.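

In this assay compound 4 gives > 30000 nM, which is a limit of the assay and not a number. This second case of chloro in place of cyano, at the position para to a large group, reads as an at least 1.5-fold higher number from compound 3 to compound 4 (0.18 log units; that floor lies within the scatter), so the step has only a floor and no measured size. The first case of this change gave a flat result, and the new pair can neither confirm that result on a second core nor show that the change behaves differently there: the same change on two cores in this assay, no change at the digits printed (within the scatter) from compound 1 to compound 2 and an at least 1.5-fold higher number (0.18 log units; that floor lies within the scatter) from compound 3 to compound 4; the limit leaves it open whether they differ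

On these data alone, the true size of the new step stays open, as does whether it would exceed the usual scatter at all. Also open, as far as these compounds go, is what a methoxy group, an amine or a carboxylic acid would do at this position on either core.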